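A few compounds are considered here, and "the series" means these few. Any claim that something is new, unique, unknown or untested is made for them only; others in the source may bear on it.

Compound 3 `O=C(O)c1cc(-n2ccnc2)ccc1O` gives 75 mg/kg in a functional assay on the whole organism for inhibition, with Rattus norvegicus as the target, read by paw edema; a higher number here means that more compound is needed for the effect, a lower number that less compound is needed. Compound 2 `O=C(O)c1ccc(-c2cscn2)cc1O`, which also carries 1,3-thiazol-4-yl, gives 70 mg/kg in this assay, within the scatter of compound 3. Compound 1 `O=C(O)c1cc(-c2csnn2)ccc1O` reaches only a limit of this assay, > 200 mg/kg. For the measured compounds named here, the one step measured at the same place of the shared core, an at least 2.6-fold lower number from compound 1 to compound 3 (0.42 log units; beyond the scatter), rests on that limit (the limit of > 200 mg/kg in this assay, at which 1 of the 3 values shown sits), so only its floor is known.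

Compound 4 `O=C(O)c1cc(-c2cscn2)ccc1O` is reached from compound 3 by the change (1,3-thiazol-4-yl in place of 1H-imidazol-1-yl on an aromatic carbon). Going by the values given here, no measured step exchanges these two groups directly; the measured step at this place shows that a ring with one nitrogen and one sulfur replaced by 1H-imidazol-1-yl lowered the number at least modestly, and compound 2 shows that 1,3-thiazol-4-yl on this core is compatible with a number close to that of compound 3. The expected step is a 1.2-fold higher number from compound 3 to compound 4 (0.08 log units; within the scatter), a small rise in the number, within or near the scatter. Compound 4 is estimated at 90 mg/kg, with a range from 45 mg/kg to 200 mg/kg.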

Compound 4, dose for half-maximal effect: 95 mg/kg
Estimate against measurement, compound 4: 1.1-fold (0.02 log units) below; the measured number falls inside the stated range.
By their numbers in this assay, from the lowest: compounds 2, 3 and 4 (each within the scatter of the next). At a limit, above all of these: compound 1.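

At this place on the shared core, the exchange of 1H-imidazol-1-yl for 1,3-thiazol-4-yl gives a 1.3-fold higher number from compound 3 to compound 4 (0.10 log units; within the scatter), so this assay does not separate these two five-membered aromatic rings. For the compounds shown here, the exchange of 1,2,3-thiadiazol-4-yl for 1,3-thiazol-4-yl gives a second step at the same place, an at least 2.1-fold lower number from compound 1 to compound 4 (0.32 log units; beyond the scatter), which shows that 1H-imidazol-1-yl is not the only group there to part from the compound at the limit. That second step rests on the limit of compound 1, so only its floor is known: the limit of > 200 mg/kg in this assay, at which 1 of the 4 values shown sits.

As far as these compounds go, how far compound 1 truly lies from compound 3 and compound 4 stays open. Also open, from the compounds shown here alone, is how a group other than a five-membered aromatic ring at this place, such as an amine or a longer alkyl chain, would read in this assay.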